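The source may report more compounds than this note shows. Statements on the series, on what has been measured and on what is new or still open speak of the compounds shown alone.

Measured compounds:
Compound 1 `O=C1O[C@@H](Cn2ccnn2)CN1c1ccc(-c2ccc(CO)nc2)c(F)c1` gives 100000 nM in a physicochemical assay for solubility, read by nephelometry; a lower number here means a less soluble compound, a higher number a more soluble compound.
Compound 2 `CN1CCN(CCCC(=O)c2ccc(-c3ccc(N4C[C@H](Cn5ccnn5)OC4=O)cc3F)cn2)CC1` gives > 400000 nM, which is a limit of this assay and not a number.
Compound 3 `O=C(c1ccc(-c2ccc(N3C[C@H](Cn4ccnn4)OC3=O)cc2F)cn1)C1CCNCC1` gives 100000 nM in this assay.

Compound 1 stands level with compound 3 at the digits shown, the step of no change at the digits printed from compound 1 to compound 3 (within the scatter) lying within the scatter, while the step of an at least 4.0-fold higher number from compound 1 to compound 2 (0.60 log units; beyond the scatter) reaches beyond it, as noted at the limit of > 400000 nM in this assay, at which 1 of the 3 values shown sits. Compound 4 `CC(C)(O)c1ccc(-c2ccc(N3C[C@H](Cn4ccnn4)OC3=O)cc2F)cn1` has not yet been measured. It differs from compound 1 by 1-hydroxy-1-methylethyl in place of hydroxymethyl on an aromatic carbon. Both measured steps replace the same hydroxymethyl group, so both bear on this one; the step of no change at the digits printed from compound 1 to compound 3 (within the scatter) is the closer precedent, and the step of an at least 4.0-fold higher number from compound 1 to compound 2 (0.60 log units; beyond the scatter) the larger. Compound 4 is therefore expected to give 100000 nM (from 50000 nM to 250000 nM). The step of no change at the digits printed from compound 1 to compound 4 (within the scatter) is expected to stay within the scatter.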

Compound 4, solubility: 200000 nM
For compound 4 the middle estimate is 2.0-fold (0.30 log units) below the measured one; low and high end bracket the measured number.
By their numbers in this assay, from the lowest: compounds 1, 3 and 4 (each within the scatter of the next). At a limit, above all of these: compound 2.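

Two added methyl groups on the carbinol carbon, giving 1-hydroxy-1-methylethyl on this aromatic carbon next to the ring nitrogen, leave this assay within the scatter: a 2.0-fold higher number from compound 1 to compound 4 (0.30 log units; within the scatter). The same holds against the piperidin-4-yl ketone: a 2.0-fold higher number from compound 3 to compound 4 (0.30 log units; within the scatter). The third step, an at least 2.0-fold lower number from compound 2 to compound 4 (0.30 log units; that floor lies within the scatter), gives only a floor, as compound 2 stands at a limit and not at a number: the limit of > 400000 nM in this assay, at which 1 of the 4 values shown sits.

The compounds shown leave open whether a carboxylic acid, a primary amine or a longer chain ending in hydroxyl at this position would move the number beyond the scatter.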